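Methoxyphenyl Sulfonamide and Its Methylphenyl Counterpart

The source may report more compounds than this note shows. Statements on the series, on what has been measured and on what is new or still open speak of the compounds shown alone.

Compound 1 `COc1ccc(NS(=O)(=O)c2ccc(NC(=O)c3ccc(Cl)cc3Cl)cc2)cc1` was examined in a functional assay on HEK293 cells for agonist activity at probable G-protein coupled receptor 27 (Homo sapiens), read by a luciferase reporter and beta-arrestin recruitment, with a stated time of 10 min; on this read-out lower numbers stand for an effect already at smaller amounts and higher numbers for an effect only at larger amounts of compound. In this assay compound 1 gives > 100000 nM, which is a limit of the assay rather than a number. That limit is shared across the set, as the limit of > 100000 nM in this assay, at which 2 of the 3 values shown sit, records. Compound 3 `O=C(Nc1ccc(Cl)cc1Cl)c1ccc(S(=O)(=O)Nc2ccccc2)cc1` likewise returns > 100000 nM, again a limit. Compound 2 `O=C(Nc1ccc(S(=O)(=O)Nc2ccccc2)cc1)c1ccc(Br)cc1F` is the only one of the three with a number, giving 479 nM in this assay. Compound 4 `Cc1ccccc1NS(=O)(=O)c1ccc(NC(=O)c2ccc(Cl)cc2Cl)cc1` is not yet measured; it differs from compound 1 by 2-methylphenyl in place of 4-methoxyphenyl on a sulfonamide nitrogen. Among the compounds with values here, no step between two measured compounds is available to size such a change. The step of a number no higher from compound 1 to compound 4 (the limit leaves the size open) that is expected is none beyond the scatter, with a limit the most likely outcome again. Compound 4 is estimated at 100000 nM, within 10000 nM to 300000 nM.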

Compound 4, half-maximal effective concentration: 1230 nM
The estimate for compound 4 lay 81-fold (1.91 log units) above the measured number; measured number below the stated range.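

Putting 2-methylphenyl in place of 4-methoxyphenyl on a sulfonamide nitrogen gives an at least 81-fold lower number from compound 1 to compound 4 (1.91 log units; beyond the scatter) in this assay. Within the data shown here, the group on this nitrogen can therefore decide whether the core of compound 1 yields a number at all, which the earlier compounds did not show. The limit still stands for part of the set: the limit of > 100000 nM in this assay, at which 2 of the 4 values shown sit.

As far as these compounds go, whether the step follows from losing 4-methoxyphenyl or from gaining 2-methylphenyl stays open. A 2-methoxyphenyl or 4-methylphenyl group on the same nitrogen would separate the group's identity from its place on the ring.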